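A few compounds are considered here, and "the series" means these few. Any claim that something is new, unique, unknown or untested is made for them only; others in the source may bear on it.

In an assay for inhibition of Fatty-acid amide hydrolase 1 (Rattus norvegicus) (a lower number here means a stronger inhibitor, a higher number a weaker inhibitor), compound 2 `O=C(O)c1ccc(-c2cnc(C(=O)CCc3ccc(-c4ccccc4)cc3)o2)cn1` gives 44 nM, the lowest of the two numbers measured here. Its nearest neighbour is compound 3 `COC(=O)c1ccc(-c2cnc(C(O)CCc3ccc(-c4ccccc4)cc3)o2)nc1`, which in this assay gives 1100 nM, a gap beyond the scatter. Compound 1 `NC(=O)c1ccc(-c2cnc(C(O)CCc3ccc(-c4ccccc4)cc3)o2)nc1` reaches only (the limit of > 1000 nM in this assay, at which 1 of the 3 values shown sits), so for compound 1 the value > 1000 nM is a limit and not a number. Going by the values given here, the one single-point step among the measured compounds, methoxy in place of amino on a carbonyl carbon, runs from compound 1 to compound 3 and is a step that the limit leaves unreadable from compound 1 to compound 3, so its size cannot be read.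

Compound 4 `COC(=O)c1ccc(-c2cnc(C(=O)CCc3ccc(-c4ccccc4)cc3)o2)nc1` has not yet been measured in this assay. It differs from compound 2 by 5-(methoxycarbonyl)pyridin-2-yl in place of 6-carboxypyridin-3-yl on an aromatic carbon. Among the compounds with values here, no measured step covers this change: the only step in hand is the unreadable one from compound 1 to compound 3, and compounds 2 and 3 differ in more than one place. On the numbers alone, compound 2 at 44 nM is the closest anchor, and the step to compound 4 is expected to be a 1.4-fold higher number from compound 2 to compound 4 (0.13 log units; within the scatter), not clearly beyond the scatter. Compound 4 is therefore estimated at 60 nM, within a range of 15 nM to 250 nM.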

Compound 4, inhibition constant: 2.2 nM
Estimate against measurement, compound 4: 27-fold (1.44 log units) above; the measured number lies below the stated range.
By their numbers in this assay, from the lowest: compound 4; then compound 2; then compound 3.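

In this assay, putting 5-(methoxycarbonyl)pyridin-2-yl in place of 6-carboxypyridin-3-yl on the aromatic carbon next to the ring oxygen gives a 20-fold lower number from compound 2 to compound 4 (1.30 log units; beyond the scatter) while the rest of the molecule stays the same. This is the first step among these compounds whose size can be read, and it shows that the number responds strongly to the group at this position. The change alters two things at once, the carboxylic acid becoming a methyl ester and the point at which the pyridine ring is attached, and nothing measured here bears on why the number moves or on which of the two matters.

On these data alone, a 5-carboxypyridin-2-yl group or a 6-(methoxycarbonyl)pyridin-3-yl group at this position would separate the effect of the ester from that of the ring attachment, so the division of this step remains open. Also open, as far as these compounds go, is how the number would respond at the same ring position to a primary amide or a nitrile, or to an ethyl ester in place of the methyl ester, with the carbonyl of the chain kept.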